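A few compounds are considered here, and "the series" means these few. Any claim that something is new, unique, unknown or untested is made for them only; others in the source may bear on it.

Measured in a functional assay on A549 cells (Homo sapiens) for inhibition, read by CCK-8 assay, with a stated time of 72 h, tested at 8 uM; a lower number here means less inhibition of growth, a higher number more inhibition of growth at the concentration tested:
compound 1, `Cc1ccc(SCc2ccc(/C=C/C(=O)Nc3ccccc3N)cc2)cc1`: 48.3%
compound 2, `COc1ccc(SCc2ccc(/C=C/C(=O)Nc3ccccc3N)cc2)cc1OC`: 80.6%
compound 3, `Nc1ccccc1NC(=O)c1ccc(CSc2ccc(Br)cc2)cc1`: 45.7%

Compound 3 holds the lowest of the three numbers; its gap to compound 1 is within the scatter, its gap to compound 2 beyond it.

Compound 4, `COc1ccc(SCc2ccc(C(=O)Nc3ccccc3N)cc2)cc1`, differs from compound 3 by methoxy in place of bromo on an aromatic carbon. Going by the values given here, the only measured step that bears on this is a number 32.3 percentage points higher from compound 1 to compound 2 (beyond the scatter), a large rise, though there 3,4-dimethoxyphenyl entered on the core of compound 1, whereas here a single methoxy enters on the core of compound 3. A rise is therefore expected in this assay, but a smaller one: the step of a number 14.3 percentage points higher from compound 3 to compound 4 (beyond the scatter) is the estimate. Compound 4 is expected to give 60%, within 42% to 78%.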

Compound 4, percent growth inhibition at one concentration: 70.7%
Compound 4: middle estimate off by 10.7 percentage points, on the low side; the measured number falls inside the stated range.
By their numbers in this assay, from the lowest: compounds 3 and 1 (each within the scatter of the next); then compounds 4 and 2 (each within the scatter of the next).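

On the core of compound 3, methoxy in place of bromo on an aromatic carbon, para to a large group, gives a number 25 percentage points higher from compound 3 to compound 4 (beyond the scatter) in this assay. A single methoxy at this position is thus enough to move the number beyond the scatter, which the 3,4-dimethoxyphenyl step on the core of compound 1 could not show. Nothing measured here gives a reason for this rise.

Going by these compounds, whether hydroxy or dimethylamino at this position would give a similar rise remains open. So does the effect of a single methoxy on the core of compound 1.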